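The compounds below may be only part of what the source reports. "The series", "measured", "known", "first", "only" and "open" are said of these compounds alone.

Of the compounds shown here, two that share one core have been tested in a functional assay on MCF7 cells (Homo sapiens) for antiproliferative activity, read by MTT assay, with a stated time of 48 h; a lower number here means a stronger inhibitor, a higher number a weaker inhibitor. Compound 1 `Fc1ccc(C2=NN(c3nc(-c4ccc(Br)cc4)cs3)C(c3ccc4c(c3)OCCO4)C2)cc1` gives 4200 nM in this assay, and compound 2 `COc1ccc(C2=NN(c3nc(-c4ccc(Br)cc4)cs3)C(c3ccc4c(c3)OCCO4)C2)cc1` gives 2540 nM. Compound 2 thus holds the lower of the two numbers, but the difference is small: the step of a 1.7-fold lower number from compound 1 to compound 2 (0.22 log units; within the scatter) lies within the scatter of repeated measurements, so the two compounds cannot be ranked against each other.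

Compound 3 `Cc1ccc(C2=NN(c3nc(-c4ccc(Br)cc4)cs3)C(c3ccc4c(c3)OCCO4)C2)cc1` has not yet been measured. It differs from compound 2 in one place only: methyl in place of methoxy on an aromatic carbon. For the measured compounds named here, the single measured step that bears on this position is the one already described, in which one small group at the same aromatic carbon was swapped for another without moving the number beyond the scatter. Going by the values given here, that is the only guide available, and it points to a small effect of substituents at this position. A step of a 1.2-fold higher number from compound 2 to compound 3 (0.07 log units; within the scatter) is therefore expected, which is no more than the scatter itself. On this basis compound 3 is estimated at 3000 nM, with a range from 1200 nM to 7500 nM.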

Compound 3, half-maximal inhibitory concentration: 1590 nM
Beside the measured number, compound 3's estimate is 1.9-fold (0.28 log units) above it; the range from low to high includes it.
By their numbers in this assay, from the lowest: compounds 3, 2 and 1 (each within the scatter of the next, the first and the last beyond it).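

In this assay the swap of methoxy for methyl gives a 1.6-fold lower number from compound 2 to compound 3 (0.20 log units; within the scatter) and so, taken alone, cannot be told apart from repeat measurement. For the compounds shown here, the new compound nevertheless shows what the first pair could not, namely that the group at this position can shift the number measurably: methyl in place of fluoro gives a 2.6-fold lower number from compound 1 to compound 3 (0.42 log units; beyond the scatter) and is the only step in the set that clears the scatter, though modestly, while compound 2 stays within the scatter of both neighbours. No measurement at hand accounts for the separation between the methyl and fluoro compounds.

Going by these compounds alone, all three compounds carry only a single small group at this place on the aromatic ring, so it remains open how the number would respond to an amine, a carboxylic acid or a longer chain such as butyl. The rest of the shared core is identical throughout, which leaves open whether changes elsewhere would matter more and whether the fluoro-to-methyl step would hold in another cell line.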